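From a Phenoxy to a Sulfanyl Link: Compound 3 Expected

The source may hold more compounds than are shown below. What is called first, only, known or untested is meant among the compounds shown, and "the series" means these compounds.

Measured compounds:
Compound 1 `Nc1cc(N)c2nc(-c3ccccc3)c(Oc3ccc(Cl)c(Cl)c3)nc2c1` — 21400 nM
Compound 2 `COc1ccc(CNc2nc3cc(N)cc(N)c3nc2-c2ccccc2)cc1OC` — 13500 nM

Of the compounds shown here, two that share one core have been measured in a functional assay on SK-MEL-28 cells (Homo sapiens) for inhibition, read by sulforhodamine B assay, with a stated time of 48 h; a lower number here means a stronger inhibitor of growth, a higher number a weaker inhibitor of growth. Compound 1 `Nc1cc(N)c2nc(-c3ccccc3)c(Oc3ccc(Cl)c(Cl)c3)nc2c1` gives 21400 nM in this assay, and compound 2 `COc1ccc(CNc2nc3cc(N)cc(N)c3nc2-c2ccccc2)cc1OC` gives 13500 nM. Compound 1 has the higher of the two numbers, but its gap to compound 2 lies within the scatter of repeated measurements, so the two cannot be told apart on these data.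

Compound 3 `Nc1cc(N)c2nc(-c3ccccc3)c(Sc3ccc(Cl)c(Cl)c3)nc2c1` has not yet been measured. It differs from compound 1 in one place: (3,4-dichlorophenyl)sulfanyl in place of 3,4-dichlorophenoxy on an aromatic carbon. Within the data shown here, no pair of measured compounds shows a step of this kind, so the numbers give no guide to its size. With the same count of heavy atoms, donors and acceptors before and after the change, the step is expected to be small, in no particular direction beyond the scatter. Compound 3 is therefore expected to give 18000 nM in this assay, with a likely range from 7000 nM to 50000 nM. The expected step from compound 1 to compound 3 is a 1.2-fold lower number from compound 1 to compound 3 (0.08 log units; within the scatter).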

Compound 3, concentration for 50% growth inhibition: 13800 nM
For compound 3 the middle estimate is 1.3-fold (0.12 log units) above the measured one; low and high end bracket the measured number.
By their numbers in this assay, from the lowest: compounds 2, 3 and 1 (each within the scatter of the next).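

In this assay, among these compounds, putting (3,4-dichlorophenyl)sulfanyl in place of 3,4-dichlorophenoxy gives a 1.6-fold lower number from compound 1 to compound 3 (0.19 log units; within the scatter), the first change in one place that can be read. At this aromatic carbon, next to the ring nitrogen and ortho to a phenyl group, the numbers therefore cannot tell the oxygen link from the sulfur link, so for this one pair the exchange leaves no mark that stands out from repeat measurements. No further measurement on these compounds bears on why the two behave alike in this test.

Among the compounds shown here, the pair tests only one change of the linking atom, with the 3,4-dichlorophenyl ring and the rest of the molecule held the same, so it remains open whether a sulfonyl link or a longer chain between the core and this ring would shift the number beyond the scatter. As far as these compounds go, it also remains open whether the same exchange would stay this small if a carboxylic acid or a nitrile took the place of the two chlorines on the ring.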